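The source may report more compounds than this note shows. Statements on the series, on what has been measured and on what is new or still open speak of the compounds shown alone.

Compound 1 `COc1ccc2[nH]c(C(=O)Cc3cccnc3)cc2c1` is, in an assay on isolated protein for inhibition of Indoleamine 2,3-dioxygenase 1 (Homo sapiens), read by spectrophotometry (on this read-out higher numbers stand for weaker inhibition and lower numbers for stronger inhibition), the compound with the lowest number of the three measured, at 49000 nM. Its closest neighbour is compound 3 `COc1ccc2[nH]c(C(=O)Cc3cccnc3)cc2c1O`, which gives 63000 nM; the step of a 1.3-fold higher number from compound 1 to compound 3 (0.11 log units; within the scatter) lies within the scatter. Compound 2 `CC(C(=O)c1cc2ccccc2[nH]1)c1cccnc1` gives 141000 nM, a higher number than that of compound 1 and the furthest from it, beyond the scatter.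

Compound 4 `O=C(Cc1cccnc1)c1cc2cc(OC(F)(F)F)ccc2[nH]1` is reached from compound 1 by a single change: trifluoromethyl in place of methyl on an oxygen on an aromatic ring. Going by the values given here, no measured step touches this position; the one step with a single change, from compound 1 to compound 3, concerns a hydroxy on an aromatic carbon and stayed within the scatter, so nothing in the data points to a shift of any particular size or direction. The account therefore expects compound 4 to sit near compound 1, with a step of a 1.0-fold higher number from compound 1 to compound 4 (0.01 log units; within the scatter) not beyond the scatter. Compound 4 is estimated at 50000 nM, with a range from 20000 nM to 125000 nM.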

Compound 4, half-maximal inhibitory concentration: 13100 nM
Compound 4: the middle estimate sits 3.8-fold (0.58 log units) above what was measured; measured number below the stated range.
By their numbers in this assay, from the lowest: compound 4; then compounds 1 and 3 (each within the scatter of the next); then compound 2.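

Trifluoromethyl in place of methyl on an oxygen on an aromatic ring gives a 3.7-fold lower number from compound 1 to compound 4 (0.57 log units; beyond the scatter) in this assay and is the only single change shown that goes beyond the scatter. Going by these compounds alone, the hydroxy step, a 1.3-fold higher number from compound 1 to compound 3 (0.11 log units; within the scatter), stayed within it, so this is the first sign that the number responds to a change in the core of compound 1, and here it responds to what sits on the oxygen. No measurement shown here accounts for the direction or size of this step.

As far as these compounds go, only one replacement on this oxygen appears, so it remains open whether an ethyl group, a longer chain or a benzyl group there would shift the number the same way. From the compounds shown here alone, it is also open whether a chlorine or an amine in place of the whole trifluoromethoxy would do so, or whether the change would carry over to the hydroxy-bearing compound 3.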